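Replacing the Indole Ring of Compound 2

This account rests on a few compounds, and the source may have more. Where it says the series, first, only, none or still open, it means among the compounds named here.

Measured compounds:
Compound 1, `O=C(/C(=C/c1ccc(Cl)cc1)Cc1ccc(Cl)c(Cl)c1)c1ccc(Cl)cc1Cl`: 1000 nM
Compound 2, `Cc1ccc(CS/C(=C/c2c[nH]c3ccc(Cl)cc23)C(=O)c2ccc(Cl)cc2)cc1`: 1000 nM
Compound 3, `COc1ccsc1/C=C(\C(=O)c1ccc(Br)cc1)S(=O)(=O)Cc1ccc(Cl)cc1`: 50000 nM

All three were tested in a functional assay on DU-145 cells (Homo sapiens) for inhibition, read by trypan blue exclusion, with a stated time of 96 h; on this read-out higher numbers stand for weaker inhibition of growth and lower numbers for stronger inhibition of growth. In this assay compound 2 gives 1000 nM, the same number at the digits shown as compound 1, and the two together sit at the low end of the three values. Compound 3 stands far away from them; its number is higher by a gap well beyond the usual scatter.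

Compound 4, `Cc1ccc(CS/C(=C/c2cc(C)ccc2C)C(=O)c2ccc(Cl)cc2)cc1`, has not yet been measured in this assay. It differs from compound 2 in one place: 2,5-dimethylphenyl in place of 5-chloro-1H-indol-3-yl on a double-bonded chain carbon bound to a double-bonded chain carbon. The group that leaves carries a hydrogen-bond donor; the group that enters has none. For the measured compounds named here, no pair of measured compounds that differ in a single place is available, so the size of this step cannot be read from any measured pair.

For compound 4 a modest weakening is expected, from compound 2 to compound 4 a 2.0-fold higher number from compound 2 to compound 4 (0.30 log units; within the scatter), though a step of no size beyond the scatter would not surprise. Compound 4 is therefore estimated at 2000 nM, with a plausible range from 500 nM to 10000 nM.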

Compound 4, concentration for 50% growth inhibition: 10000 nM
Compound 4: middle estimate off by 5.0-fold (0.70 log units), on the low side; measured number inside the range.
By their numbers in this assay, from the lowest: compounds 1 and 2 (each within the scatter of the next); then compound 4; then compound 3.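

In this assay the group on this double-bonded chain carbon turns out to matter: 2,5-dimethylphenyl in place of 5-chloro-1H-indol-3-yl gives a 10-fold higher number from compound 2 to compound 4 (1.00 log units; beyond the scatter) and so moves the number well beyond the usual scatter. This is the first change in one place among these compounds, and it shows that, at this position, one aromatic group cannot simply stand in for the other without a clear loss of growth inhibition. The change removes the five-membered aromatic ring, the chlorine and the hydrogen-bond donor all at once, and no measurement at hand says why the number rises.

Which of those three parts carries the difference stays open, since the two compounds differ in all of them together; a 5-chloro-1-methyl-1H-indol-3-yl group, or an unchlorinated 1H-indol-3-yl group, on the same carbon would begin to pull them apart. From the compounds shown here alone, it is also open whether the same swap would have a step of similar size on the differing cores of compound 1 or compound 3.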